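Swapping a Basic Amine for a Piperidine Amide

The source may report more compounds than this note shows. Statements on the series, on what has been measured and on what is new or still open speak of the compounds shown alone.

Of the compounds shown here, three sharing one core have been tested in a functional assay with Oryctolagus cuniculus as the target; on this read-out higher numbers stand for weaker inhibition and lower numbers for stronger inhibition. Compound 1 `COc1ccc(-c2nc(CN(C)C)sc2-c2ccc(OC)cc2)cc1` gives 96 nM, the highest of the three numbers. Compound 2 `COc1ccc(-c2nc(CNC(=O)C3=NNC(=O)CC3)sc2-c2ccc(OC)cc2)cc1` gives 55 nM, and compound 3 `COc1ccc(-c2nc(CNC(=O)NC(C)C)sc2-c2ccc(OC)cc2)cc1` gives 42 nM. The step of a 1.7-fold lower number from compound 1 to compound 2 (0.24 log units; within the scatter) stays within the scatter, while a 2.3-fold lower number from compound 1 to compound 3 (0.36 log units; beyond the scatter) is modest. Compound 4 `COc1ccc(-c2nc(C(=O)N3CCCCC3)sc2-c2ccc(OC)cc2)cc1` has not been measured; it differs from compound 1 by (piperidin-1-yl)carbonyl in place of (dimethylamino)methyl on an aromatic carbon. Both measured steps exchange only the dimethylamino group for a carbonyl-bearing group on the saturated chain carbon, whereas here the whole (dimethylamino)methyl group is replaced on the aromatic carbon, so they bear on this change only loosely. A small lowering or no change beyond the scatter is expected, a 1.5-fold lower number from compound 1 to compound 4 (0.17 log units; within the scatter). Compound 4 is therefore estimated to give 65 nM, between 20 nM and 220 nM.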

Compound 4, half-maximal inhibitory concentration: > 1000 nM
Compound 4 was reported as a limit; the forecaster's own chance of this, stated with the estimate: 5%; middle value at least 15-fold (1.18 log units) from the limit.
By their numbers in this assay, from the lowest: compounds 3, 2 and 1 (each within the scatter of the next, the first and the last beyond it). At a limit, above all of these: compound 4.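

In this assay, this position tolerated different groups on the saturated chain carbon in compounds 1, 2 and 3, but not this change, which puts a carbonyl directly on the aromatic carbon: an at least 10-fold higher number from compound 1 to compound 4 (1.01 log units; beyond the scatter), and an at least 23-fold higher number from compound 3 to compound 4 (1.37 log units; beyond the scatter). So the group on this aromatic carbon matters far more than the earlier compounds suggested. Compound 4 has only a limit, not a number: the limit of > 1000 nM in this assay, at which 1 of the 4 values shown sits.

The compounds shown leave open whether the loss of the saturated chain carbon or the arrival of the piperidine ring drives this. A (piperidin-1-yl)methyl group and a (dimethylamino)carbonyl group on the same carbon would separate the two.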